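This account rests on a few compounds, and the source may have more. Where it says the series, first, only, none or still open, it means among the compounds named here.

Within the data shown here, compound 2 `O=C(COc1ccc2cc(C(O)(C(F)(F)F)C(F)(F)F)c(O)cc2c1)Nc1ccc(-c2ccccc2)cc1` gives 2800 nM in an assay on isolated protein for inhibition of tyrosine-protein phosphatase non-receptor type 13 (Homo sapiens), read by spectrophotometry (a lower number here means a stronger inhibitor, a higher number a weaker inhibitor), the only actual number among the three measured compounds. Compound 1 `CCCNC(=O)COc1ccc2cc(C(O)(C(F)(F)F)C(F)(F)F)c(O)cc2c1` reaches only the assay limit of > 20000 nM. Compound 3 `Oc1cc(-c2ccccc2)ccc1C(O)(C(F)(F)F)C(F)(F)F` likewise stops at a limit, > 500000 nM. Among the measured compounds shown here, the one measured step, an at least 7.1-fold lower number from compound 1 to compound 2 (0.85 log units; beyond the scatter), bears directly on the new compound. Compound 4 `O=C(COc1ccc2cc(C(O)(C(F)(F)F)C(F)(F)F)c(O)cc2c1)NCc1ccccc1` differs from compound 2 by benzyl in place of 4-phenylphenyl on an amide-type nitrogen. The gain of an at least 7.1-fold lower number from compound 1 to compound 2 (0.85 log units; beyond the scatter) came with 4-phenylphenyl; benzyl removes part of that group, so compound 4 is expected to sit weaker than compound 2 while keeping an aromatic ring that propyl lacked. Compound 4 is therefore estimated at 8000 nM, with a range of 3000 nM to 25000 nM. The expected step is a 2.9-fold higher number from compound 2 to compound 4 (0.46 log units; beyond the scatter).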

Compound 4, half-maximal inhibitory concentration: > 20000 nM
Compound 4: no number, only a limit; the forecaster's own chance of this, stated with the estimate: 25%; middle value at least 2.5-fold (0.39 log units) away from the limit.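

In this assay, benzyl in place of 4-phenylphenyl on the amide-type nitrogen gives an at least 7.1-fold higher number from compound 2 to compound 4 (0.85 log units; beyond the scatter) and so loses the whole measurable gain. One aromatic ring on that nitrogen is therefore not enough here; the full 4-phenylphenyl group is needed for a readable value. The value of compound 4 is a limit, and the step from compound 1 to compound 4 cannot be read because both sit at the same limit: the limit of > 20000 nM in this assay, at which 2 of the 4 values shown sit.

As far as these compounds go, it remains open whether phenyl or phenethyl on that nitrogen would restore a readable value. From the compounds shown here alone, it is also open whether a carboxylic acid on the outer ring of 4-phenylphenyl would strengthen or weaken compound 2.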